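The compounds below may be only part of what the source reports. "The series", "measured", "known", "first", "only" and "open" are said of these compounds alone.

Measured compounds in an assay on CHO cells for displacement of a labelled ligand from adenosine receptor A1 (Homo sapiens), read by scintillation counting, tested at 10 uM; a lower number here means less inhibition, a higher number more inhibition at the concentration tested (going by the name of the read-out):
compound 1 `CC(C)(C)Cc1c(-c2ccoc2)sc(N)c1C(=O)c1ccc(Cl)cc1` — 1%
compound 2 `CC(C)(C)Cc1c(-c2cccnc2)sc(N)c1C(=O)c1ccc(Cl)cc1` — 1%
compound 3 `CC(C)(C)Cc1c(-c2ccc(Cl)cc2)sc(N)c1C(=O)c1ccc(Cl)cc1` — 1%

All three measured compounds share one core and differ only in the aromatic group attached to it. In this assay compound 3 gives 1%, and compound 1 and compound 2 sit level with it at the digits shown. The three steps among them, no change at the digits printed from compound 1 to compound 2 (within the scatter), no change at the digits printed from compound 1 to compound 3 (within the scatter) and no change at the digits printed from compound 2 to compound 3 (within the scatter), are all within the scatter, so exchanging the aromatic group among the three variants tried has produced no change that can be read.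

The next compound, compound 4 `CC(C)(C)Cc1c(-c2ccc(Cl)c(Cl)c2)sc(N)c1C(=O)c1ccc(Cl)cc1`, differs from compound 3 by chloro in place of hydrogen on an aromatic carbon. Going by the values given here, no measured step adds a chloro group to the aromatic group; the closest precedent is the whole swap of that group, which moved nothing. With all three measured values at the floor and every step flat, the step of a number 1 percentage points higher from compound 3 to compound 4 (within the scatter) is expected to remain within the scatter. Compound 4 is therefore estimated to give 2%, with a range from -8% to 12%.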

Compound 4, a percentage reported as inhibition, at one concentration (the size of the read-out at that concentration, not a potency): 1%
Compound 4: the middle estimate sits 1 percentage points above what was measured, and the stated range covers the measured number.
By their numbers in this assay, from the lowest: compounds 1, 2, 3 and 4 (each within the scatter of the next).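

In this assay a chloro entering on an aromatic carbon ortho to a chloro group gives no change at the digits printed from compound 3 to compound 4 (within the scatter) and so adds the first read on a substitution within the aromatic group, as opposed to an exchange of the whole group. The 3,4-dichlorophenyl variant also shows no change at the digits printed from compound 2 to compound 4 (within the scatter) and no change at the digits printed from compound 1 to compound 4 (within the scatter) and this extends the flat picture at this position to four aromatic groups. Nothing available explains this flat result.

Going by these compounds, all four values remain at the floor, so it stays open whether any substitution at this position can raise inhibition. An amine or a carboxylic acid on the aromatic group might show this, and a longer chain in place of that group would test the same question.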